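This account rests on a few compounds, and the source may have more. Where it says the series, first, only, none or still open, it means among the compounds named here.

Measured so far:
compound 1 `Cc1cccc(-c2cc(O)c3ccc(C)nc3n2)c1`: 97.7 nM
compound 2 `Oc1cc(-c2ccc3ccccc3c2)nc2ncccc12`: 8130 nM
compound 3 `Cc1cccc(-c2cc(O)c3c(C)cc(C)nc3n2)c1`: 38000 nM

In a functional assay on cells (Tumor Cell line, Homo sapiens) for antiproliferative activity (on this read-out lower numbers stand for stronger inhibition of growth and higher numbers for weaker inhibition of growth), compound 1 gives 97.7 nM and stands well apart from the other two. Compound 3 differs from compound 1 by methyl in place of hydrogen on an aromatic carbon. This single change gave a 390-fold higher number from compound 1 to compound 3 (2.59 log units; beyond the scatter), a very large loss of growth inhibition. Compound 2 carries a different core; the difference between the core of compound 1 and the core of compound 2 is not broken down here. In this assay compound 2 gives 8130 nM, which is weaker than compound 1 but stronger than compound 3, both gaps lying beyond the scatter.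

Compound 4 `Cc1cnc2nc(-c3ccc4ccccc4c3)cc(O)c2c1` is not yet measured. It differs from compound 2 by methyl in place of hydrogen on an aromatic carbon. Among the measured compounds shown here, this is the same kind of change as the one from compound 1 to compound 3, not the same: in compound 3 the methyl sits ortho to a fused ring, meta to a methyl group and opposite the ring nitrogen, whereas in compound 4 it sits two atoms from the ring nitrogen and para to a fused ring. For the measured compounds named here, only one measured example of this kind of change exists, and it was made on a different core. Because the earlier step was a 390-fold higher number from compound 1 to compound 3 (2.59 log units; beyond the scatter), a loss is the more likely direction, but with compound 2 already weak and the methyl placed differently, a smaller step is expected. Compound 4 is expected to give 30000 nM, with a range from 8000 nM to 120000 nM. This estimate corresponds to an expected step of a 3.7-fold higher number from compound 2 to compound 4 (0.57 log units; beyond the scatter).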

Compound 4, concentration for 50% growth inhibition: 741 nM
The estimate for compound 4 lay 40-fold (1.61 log units) above the measured number; measured number below the stated range.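

In this assay the methyl in place of hydrogen gives an 11-fold lower number from compound 2 to compound 4 (1.04 log units; beyond the scatter), a large gain in growth inhibition where the same kind of change on the other core was a large loss. The two steps run in opposite directions, so in this series the change cannot be carried from one core to another as a fixed increment: the same change on two cores in this assay, a 390-fold higher number (2.59 log units; beyond the scatter) from compound 1 to compound 3 and an 11-fold lower number (1.04 log units; beyond the scatter) from compound 2 to compound 4, 4300-fold (3.63 log units) apart, beyond the scatter of two such steps. This does not show what sets the direction: the two steps differ both in the core and in where the methyl sits, here two atoms from the ring nitrogen and para to a fused ring, and with one step on each core these two differences cannot be separated, nor can a rule for the series be drawn.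

The compounds shown leave open whether a methyl at this same place on the core of compound 1 would also lower the number, which would help to separate the role of the core from that of the position. They also leave open whether the gain seen with compound 4 is particular to methyl or extends to other groups on that carbon, such as ethyl, methoxy or an amine.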